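Piperidine for acetylpiperazine at two different attachment sites

The compounds below may be only part of what the source reports. "The series", "measured", "known", "first", "only" and "open" are said of these compounds alone.

Measured in an assay on isolated protein for displacement of a labelled ligand from 5-hydroxytryptamine receptor 6 (Homo sapiens), read by scintillation counting, with a stated time of 1 h; on this read-out higher numbers stand for weaker inhibition and lower numbers for stronger inhibition:

compound 1 `CC(=O)N1CCN(c2cn(S(=O)(=O)c3ccccc3)c3ccccc23)CC1` gives 97 nM
compound 2 `O=S(=O)(c1ccccc1)n1cc(N2CCCCC2)c2ccccc21` gives 219 nM
compound 3 `CC(=O)N1CCN(c2ccc3c(ccn3S(=O)(=O)c3ccccc3)c2)CC1` gives 4850 nM

Compound 1 and compound 2 share a core and differ only in the group on the five-membered ring: piperidin-1-yl in place of 4-acetylpiperazin-1-yl on an aromatic carbon. That change gives a 2.3-fold higher number from compound 1 to compound 2 (0.35 log units; beyond the scatter).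

Compound 3 carries the same acetylpiperazine group but on a different part of the shared core; how the two cores differ is not broken down here, and compound 3 sits far higher in this assay than both compound 1 and compound 2.

Compound 4 `O=S(=O)(c1ccccc1)n1ccc2cc(N3CCCCC3)ccc21` is not yet measured. It arises from compound 3 by piperidin-1-yl in place of 4-acetylpiperazin-1-yl on an aromatic carbon. This is the same kind of change as that from compound 1 to compound 2, but not the same: in the first case the group sits on a five-membered aromatic ring with one nitrogen, two ring bonds from the ring nitrogen and from the ring atom bearing the phenylsulfonyl group; here it sits on a six-membered aromatic ring of carbon only, meta to a fused ring and para to a fused ring.

Among the compounds with values here, for compound 4 the step is expected to be a 2.0-fold higher number from compound 3 to compound 4 (0.29 log units; within the scatter), of about the size seen for compound 2 because a 2.3-fold higher number from compound 1 to compound 2 (0.35 log units; beyond the scatter) is the only precedent for the swap, with wider uncertainty owing to the different attachment site. Compound 4 is thus estimated at 9500 nM in this assay, plausibly between 3000 nM and 30000 nM.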

Compound 4, inhibition constant: 360 nM
For compound 4 the middle estimate is 26-fold (1.42 log units) above the measured one, and the stated range ends above it.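

In this assay, piperidin-1-yl in place of 4-acetylpiperazin-1-yl on an aromatic carbon of a six-membered aromatic ring of carbon only gives a 13-fold lower number from compound 3 to compound 4 (1.13 log units; beyond the scatter) and so does not repeat the outcome on the other core, where the same swap moves the number the opposite way: the same change on two cores in this assay, a 2.3-fold higher number (0.35 log units; beyond the scatter) from compound 1 to compound 2 and a 13-fold lower number (1.13 log units; beyond the scatter) from compound 3 to compound 4, 30-fold (1.48 log units) apart, beyond the scatter of two such steps. This shows that, across these two pairs, the result of the swap on one core does not carry over to the other in direction or in size, so neither step can stand in as a general value for this change in the series. It does not show what sets the two steps apart, since the pairs offer only two examples, and the difference between the cores is not separated into parts by any compound shown.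

Still open, going by these compounds, is whether the large step on the core of compound 3 comes from losing the acetyl group or from replacing the whole ring, which a piperazine with a free amine at that place would help to separate. Open too, on these data alone, is whether a morpholine in the same place on each core would follow the pattern of either pair.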